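The source may hold more compounds than are shown below. What is called first, only, known or untested is meant among the compounds shown, and "the series" means these compounds.

Measured so far in a functional assay on PC-3 cells (Homo sapiens) for cytotoxicity, read by MTT assay, with a stated time of 72 h; a lower number here means a stronger inhibitor, a higher number a weaker inhibitor:
- compound 1, `O=C(Nc1ccc(Oc2ccnc3[nH]ccc23)c(F)c1)c1nn(-c2ccc(Cl)c(F)c2)ccc1=O`: 13600 nM
- compound 2, `Cn1ccc2c(Oc3ccc(NC(=O)c4nn(-c5ccccc5)ccc4=O)cc3F)ccnc21`: a limit, > 60000 nM
- compound 3, `Cn1ccc2c(Oc3ccc(NC(=O)c4nn(-c5ccc(Br)cc5F)ccc4=O)cc3F)ccnc21`: 16300 nM

Among the two compounds with a numerical result, compound 3 has the higher number, but its nearest neighbour is compound 1, and the gap between these two lies within the usual scatter, so no order can be read from it. For compound 2 this assay gives only a limit, not a number (the limit of > 60000 nM in this assay, at which 1 of the 3 values shown sits).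

Compound 4, `Cn1ccc2c(Oc3ccc(NC(=O)c4nn(-c5ccc(Cl)c(F)c5)ccc4=O)cc3F)ccnc21`, differs from compound 3 in one place: 4-chloro-3-fluorophenyl in place of 4-bromo-2-fluorophenyl on an aromatic nitrogen. For the measured compounds named here, the one measured step that touches this position is the change from a plain phenyl to a halogen-bearing phenyl, an at least 3.6-fold lower number from compound 2 to compound 3 (0.56 log units; beyond the scatter). The step to compound 4 keeps a halogen-bearing phenyl and only moves the halogens about, so it is a smaller change than that one. Compound 1 carries the same 4-chloro-3-fluorophenyl as compound 4 on a closely related core, and its number sits within the scatter of the number of compound 3. The step from compound 3 to compound 4 is therefore expected to stay within the scatter, a 1.3-fold lower number from compound 3 to compound 4 (0.10 log units; within the scatter). For compound 4 the expected value in this assay is 13000 nM, with a range from 5000 nM to 35000 nM.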

Compound 4, half-maximal inhibitory concentration: 17900 nM
The estimate for compound 4 lay 1.4-fold (0.14 log units) below the measured number; low and high end bracket the measured number.
By their numbers in this assay, from the lowest: compounds 1, 3 and 4 (each within the scatter of the next). At a limit, above all of these: compound 2.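

In this assay, the new result shows that this position tolerates a rearrangement of the halogens without a readable difference: 4-chloro-3-fluorophenyl and 4-bromo-2-fluorophenyl give a 1.1-fold higher number from compound 3 to compound 4 (0.04 log units; within the scatter), and the methyl in place of hydrogen on the aromatic nitrogen of the shared core also stays within the scatter, with a 1.3-fold higher number from compound 1 to compound 4 (0.12 log units; within the scatter). The earlier drop from the plain phenyl is therefore not tied to a single halogen pattern, as a second pattern also gives a step beyond the scatter, an at least 3.3-fold lower number from compound 2 to compound 4 (0.52 log units; beyond the scatter). Compound 2 gives a limit, not a number, so the true size of both steps away from it remains unknown: the limit of > 60000 nM in this assay, at which 1 of the 4 values shown sits.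

On these data alone, it remains open whether halogens as such matter, or whether a phenyl carrying another group, such as a methoxy group, an amine or a carboxylic acid, would give a similar number. The compounds shown also leave open how a phenyl with a single fluorine or a single chlorine would compare, and so whether one halogen is enough for the step away from plain phenyl.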